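Shortening the Amide Chain of a Benzophenone Analogue

This account rests on a few compounds, and the source may have more. Where it says the series, first, only, none or still open, it means among the compounds named here.

Within the data shown here, compound 3 `CCCCCC(=O)NCC(=O)N(C)c1ccc(Cl)cc1C(=O)c1ccccc1Cl` gives 90 mg/kg in a functional assay on the whole organism with Mus musculus as the target, in the rotarod test (a lower number here means that less compound is needed, a higher number that more compound is needed for the effect), the highest number among the three compounds measured so far. The other two carry a nitrogen at the chain end in place of the butyl: compound 1 `CN(C)CC(=O)NCC(=O)N(C)c1ccc(Cl)cc1C(=O)c1ccccc1Cl` gives 26 mg/kg in this assay, and compound 2 `CN(C(=O)CNC(=O)CN)c1ccc(Cl)cc1C(=O)c1ccccc1Cl` gives 27.7 mg/kg. The steps of a 3.5-fold higher number from compound 1 to compound 3 (0.54 log units; beyond the scatter) and a 3.2-fold higher number from compound 2 to compound 3 (0.51 log units; beyond the scatter) show that swapping a small nitrogen-bearing group for the butyl chain pushed the number upward by a modest amount, while a 1.1-fold higher number from compound 1 to compound 2 (0.03 log units; within the scatter) shows that the two nitrogen-bearing chain ends behave alike.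

Compound 4 `CCCCC(=O)NCC(=O)N(C)c1ccc(Cl)cc1C(=O)c1ccccc1Cl` differs from compound 3 only in hydrogen in place of methyl on a saturated chain carbon, four bonds along the chain from a carbonyl carbon. Among the measured compounds shown here, no measured step removes a single methyl from the chain end, so the expectation leans on the modest size of the butyl-for-amine steps and on the smallness of this change. Compound 4 is therefore expected to stay close to compound 3, at an estimated 75 mg/kg with a range of 40 mg/kg to 140 mg/kg, a step of a 1.2-fold lower number from compound 3 to compound 4 (0.08 log units; within the scatter) that is expected to fall within the scatter.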

Compound 4, dose for half-maximal effect: 90 mg/kg
Compound 4: middle estimate off by 1.2-fold (0.08 log units), on the low side; measured number inside the range.
By their numbers in this assay, from the lowest: compounds 1 and 2 (each within the scatter of the next); then compounds 3 and 4 (each within the scatter of the next).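

Trimming the butyl chain to propyl, hydrogen in place of methyl four bonds along the chain from a carbonyl carbon, leaves the number in this assay where it was, with no change at the digits printed from compound 3 to compound 4 (within the scatter). The gap to the nitrogen-bearing chain ends survives this shortening, with a 3.2-fold higher number from compound 2 to compound 4 (0.51 log units; beyond the scatter) and a 3.5-fold higher number from compound 1 to compound 4 (0.54 log units; beyond the scatter), so the propyl chain of compound 4 sits with the butyl chain of compound 3, apart from the amino of compound 2 and the dimethylamino of compound 1. Nothing measured here explains why the end methyl makes no visible difference.

As far as these compounds go, whether a shorter ethyl chain or a longer hexyl chain would also hold the number stays open. So does the question of where a carboxylic acid at the chain end would fall.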